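Selenium-linked bis-acyl ureas: benzyl to methyl step

This account rests on a few compounds, and the source may have more. Where it says the series, first, only, none or still open, it means among the compounds named here.

Measured so far in a functional assay on HepG2 cells (Homo sapiens) for cytotoxicity, read by MTT assay, with a stated time of 72 h; on this read-out higher numbers stand for weaker inhibition of growth and lower numbers for stronger inhibition of growth:
- compound 1 `O=C(/N=C(/NC(=O)c1ccno1)[Se]Cc1ccccc1)c1ccno1`: compound 1 gives 58900 nM
- compound 2 `C[Se]/C(=N\C(=O)c1ccno1)NC(=O)c1ccno1`: compound 2 gives 9350 nM
- compound 3 `O=C(/N=C(/NC(=O)c1csc([N+](=O)[O-])c1)[Se]Cc1ccccc1)c1csc([N+](=O)[O-])c1`: compound 3 gives 62800 nM

Among the compounds with values here, the one step measured within a single core is a 6.3-fold lower number from compound 1 to compound 2 (0.80 log units; beyond the scatter), brought about by the change (hydrogen in place of phenyl on a saturated chain carbon bound to a selenium atom). Compound 3 carries a different core from compound 1; how the two cores differ is not broken down here. The values of compound 3 and compound 1 in this assay lie within the scatter of each other, so no order between them is read.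

Compound 4 `C[Se]/C(=N\C(=O)c1csc([N+](=O)[O-])c1)NC(=O)c1csc([N+](=O)[O-])c1` stands to compound 3 as compound 2 stands to compound 1: the change is hydrogen in place of phenyl on a saturated chain carbon bound to a selenium atom, at a place described in the same words as for the earlier pair, so it is the same change made on the second core. Within the data shown here, the expected step is a 5.2-fold lower number from compound 3 to compound 4 (0.72 log units; beyond the scatter), resting on the single precedent, because the step of a 6.3-fold lower number from compound 1 to compound 2 (0.80 log units; beyond the scatter) was made by this change on the first core; with only one precedent, a somewhat smaller step is allowed for. Compound 4 is therefore estimated at 12000 nM in this assay, with an expected range from 4000 nM to 40000 nM.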

Compound 4, concentration for total growth inhibition: 1550 nM
Compound 4: the middle estimate sits 7.7-fold (0.89 log units) above what was measured, outside the stated range (below it).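

In this assay the benzyl to methyl change gives a 41-fold lower number from compound 3 to compound 4 (1.61 log units; beyond the scatter) on the second core, so the direction seen on the first core recurs. The size of the step does not carry over unchanged: the same change on two cores in this assay, a 6.3-fold lower number (0.80 log units; beyond the scatter) from compound 1 to compound 2 and a 41-fold lower number (1.61 log units; beyond the scatter) from compound 3 to compound 4, 6.4-fold (0.81 log units) apart, beyond the scatter of two such steps. Within the data shown here, with only two cores, the series supports the direction of this change for these two pairs and shows that its size differs with the core, but it gives no rule for the size of the step on a further core and does not identify which difference between the cores goes with the larger step.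

The compounds shown carry only benzyl and methyl as the group bound to the selenium atom, so it remains open whether a longer chain such as ethyl or butyl would fall between them or outside them. On these data alone, how a chain bearing an amine or a carboxylic acid in that place would read in this assay also remains open.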